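This account rests on a few compounds, and the source may have more. Where it says the series, first, only, none or still open, it means among the compounds named here.

Measured values in a functional assay on WiDr cells (Homo sapiens) for antiproliferative activity, read by sulforhodamine B assay, with a stated time of 48 h (a lower number here means a stronger inhibitor of growth, a higher number a weaker inhibitor of growth), are these:

- compound 1 `CC(C)(C)[Si](C)(C)O[C@@H]1CCCO[C@@H]1CO` gives > 100000 nM
- compound 2 `CC(C)(C)[Si](C)(C)O[C@@H]1CCCO[C@@H]1/C=C\C(=O)OCc1ccccc1` gives 20000 nM
- compound 3 `COC(=O)/C=C\[C@H]1OCCC[C@H]1O[Si](C)(C)C(C)(C)C` gives 38000 nM

Compound 1 stands at the limit of > 100000 nM in this assay, at which 1 of the 3 values shown sits; this is a limit and not a number. Among the compounds with values here, only two true numbers remain, and they are not separated: a 1.9-fold higher number from compound 2 to compound 3 (0.28 log units; within the scatter). Against the limit entry, the step reads an at least 2.6-fold lower number from compound 1 to compound 3 (0.42 log units; beyond the scatter).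

Compound 4 `CC(C)(C)[Si](C)(C)O[C@@H]1CCCO[C@@H]1/C=C\CO` is reached by hydroxymethyl in place of methoxycarbonyl on a double-bonded chain carbon bound to a double-bonded chain carbon. Within the data shown here, no measured step makes this exact change. The ester change in compound 2 offers little guidance, given a 1.9-fold higher number from compound 2 to compound 3 (0.28 log units; within the scatter). Compound 1 also carries hydroxymethyl, though on a saturated ring carbon, and so gives only a loose hint through an at least 2.6-fold lower number from compound 1 to compound 3 (0.42 log units; beyond the scatter).

A small move toward a higher number is therefore expected in this assay, estimated as a 1.4-fold higher number from compound 3 to compound 4 (0.16 log units; within the scatter). For compound 4 the estimated value is 55000 nM, with an expected range from 25000 nM to 120000 nM.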

Compound 4, concentration for 50% growth inhibition: > 100000 nM
Compound 4: a limit, no number (the forecaster's own chance of this, stated with the estimate: 25%); at least 1.8-fold (0.25 log units) between middle value and limit.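

In this assay, within the data shown here, the earlier compounds held no step at this place, and replacing methoxycarbonyl with hydroxymethyl on the double-bonded chain carbon gives an at least 2.6-fold higher number from compound 3 to compound 4 (0.42 log units; beyond the scatter). The value of compound 4 is a limit and not a number: the limit of > 100000 nM in this assay, at which 2 of the 4 values shown sit. Among these four compounds, the two carrying a terminal hydroxymethyl, compound 1 and compound 4, sit at that limit, while the two esters, compound 2 and compound 3, give numbers, and no compound shown goes against this.

The step from compound 1 to compound 4 cannot be read, since both values are limits. On these data alone, whether the ester as a whole or the free hydroxyl sets the step stays open, and a methyl ether, a carboxylic acid or an amide at the same place would bear on this.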